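A few compounds are considered here, and "the series" means these few. Any claim that something is new, unique, unknown or untested is made for them only; others in the source may bear on it.

Measured compounds:
compound 1 `CC(C)=CCC[C@]1(C)/C=C/[C@@H](OC(=O)C=C(C)C)[C@](C)(O)/C=C/C(=O)/C(CN2CCN(C)CC2)=C\C1`: 840 nM
compound 2 `CC(C)=CCC[C@]1(C)/C=C/[C@@H](OC(=O)C=C(C)C)[C@](C)(O)/C=C/[C@H](O)/C(CO)=C\C1`: > 40000 nM

Going by the values given here, in a functional assay on HL-60 cells (Homo sapiens) for antiproliferative activity, read by MTT assay, with a stated time of 48 h (on this read-out lower numbers stand for stronger inhibition and higher numbers for weaker inhibition), compound 1 gives 840 nM and is the only compound of the pair with a numerical value. Compound 2 reaches only a limit of this assay, namely > 40000 nM, which is the limit of > 40000 nM in this assay, at which 1 of the 2 values shown sits. Among the compounds with values here, compound 1 and compound 2 differ in more than one place, so no single step can be read between them; their values show only that compound 2 falls off the measurable range while compound 1 does not.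

Compound 3 `CC(C)=CCC[C@]1(C)/C=C/[C@@H](OC(=O)C=C(C)C)[C@](C)(O)/C=C/C(=O)/C(C(=O)N(C(C)C)C(C)C)=C\C1` is not yet measured. It keeps the enone of compound 1 and changes one substituent: diisopropylcarbamoyl in place of (4-methylpiperazin-1-yl)methyl on a double-bonded ring carbon. Within the data shown here, no measured step covers this change. The expected step is toward weaker inhibition, beyond the usual scatter, written as a 4.2-fold higher number from compound 1 to compound 3 (0.62 log units; beyond the scatter). For compound 3 the estimate in this assay is 3500 nM, with a range from 900 nM to 14000 nM.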

Compound 3, half-maximal inhibitory concentration: 12700 nM
The estimate for compound 3 lay 3.6-fold (0.56 log units) below the measured number; the range from low to high includes it.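

In this assay, the double-bonded ring carbon three ring bonds from the ring atom bearing the 4-methylpent-3-en-1-yl group proves sensitive to its substituent: with the enone kept, diisopropylcarbamoyl in place of (4-methylpiperazin-1-yl)methyl reads as a 15-fold higher number from compound 1 to compound 3 (1.18 log units; beyond the scatter). This is the only single-place step shown, and the change weakens inhibition without ending the numerical read-out, as compound 3 gives 12700 nM. Nothing shown gives a cause for this step.

On these data alone, whether the step follows the piperazine ring or the carbonyl stays open; a morpholin-4-ylmethyl, a dimethylaminomethyl or a 4-methylpiperazine-1-carbonyl group on the same carbon would separate these. As far as these compounds go, how far the step holds on other cells also stays open.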